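The source may report more compounds than this note shows. Statements on the series, on what has been measured and on what is new or still open speak of the compounds shown alone.

Compound 1 `C=C1CC[C@@H]2[C@](C)(CO)[C@H](O)CC[C@@]2(C)[C@@H]1CC=O` in a functional assay on BMMC cells (Mus musculus, strain C57BL/6) for inhibition, with stated times of 5 days and 48 h (a higher number here means a weaker inhibitor, a lower number a stronger inhibitor), gives no number, only the assay limit of > 30000 nM. Compound 2 `C=C1CC[C@@H]2[C@](C)(CO)[C@H](O)CC[C@@]2(C)[C@@H]1C/C=C(/C(=O)O)[C@H](O)CO` likewise stays at the limit, > 30000 nM. Going by the values given here, compound 3 `C=C1CC[C@@H]2[C@](C)(CNCc3ccc(F)cc3)[C@H](O)CC[C@@]2(C)[C@@H]1/C=C/C1=CCOC1=O` gives 350 nM, and this is the sole numeric value in the set. Among the compounds with values here, the other two entries share (the limit of > 30000 nM in this assay, at which 2 of the 3 values shown sit), so compound 3 stands alone as the one compound with a measured potency; no step between measured compounds can be read from this. Compound 4 `C=C1CC[C@@H]2[C@](C)(CNCc3cccs3)[C@H](O)CC[C@@]2(C)[C@@H]1/C=C/C1=CCOC1=O` differs from compound 3 by thiophen-2-yl in place of 4-fluorophenyl on a saturated chain carbon bound to an amine nitrogen. The expected step from compound 3 to compound 4 is a 1.1-fold higher number from compound 3 to compound 4 (0.06 log units; within the scatter), that is, no change beyond the usual scatter in either direction. Compound 4 is accordingly estimated at 400 nM, with a range from 150 nM to 1200 nM.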

Compound 4, half-maximal inhibitory concentration: 1070 nM
Beside the measured number, compound 4's estimate is 2.7-fold (0.43 log units) below it, within the range that was stated.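

In this assay, thiophen-2-yl in place of 4-fluorophenyl on a saturated chain carbon bound to an amine nitrogen gives a 3.1-fold higher number from compound 3 to compound 4 (0.49 log units; beyond the scatter), a modest step that shows this position responds to the aromatic group it carries. Going by these compounds alone, compound 1 and compound 2 differ from these two in more than one place, so no steps to them can be read. Nothing at hand bears on the cause of this step.

On these data alone, whether an unsubstituted phenyl, a pyridine ring or a longer chain on the amine nitrogen would read closer to compound 3 or to compound 4 stays open. So does the effect of an amide at that nitrogen.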